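A Nitro-Bearing Ring in Place of a Dichlorinated One

The source may report more compounds than this note shows. Statements on the series, on what has been measured and on what is new or still open speak of the compounds shown alone.

Of the compounds shown here, three built on one shared core have been tested in a functional assay on HepG2 cells (Homo sapiens) for inhibition, read by MTT assay, with a stated time of 72 h; on this read-out higher numbers stand for weaker inhibition and lower numbers for stronger inhibition. Compound 1 `CN(C(=O)NC(=O)c1cccc(C(F)(F)F)c1)c1nc(C(F)(F)F)c(C(=O)N/N=C/c2ccccc2C(F)(F)F)s1` gives 10.4 ug/mL. Compound 2 `CN(C(=O)NC(=O)c1c(Cl)cccc1Cl)c1nc(C(F)(F)F)c(C(=O)N/N=C/c2ccccc2C(F)(F)F)s1` gives 8.95 ug/mL, and compound 3 `Cc1nc(N(C)C(=O)NC(=O)c2c(F)cccc2F)sc1C(=O)N/N=C/c1cc(C(F)(F)F)cc(C(F)(F)F)c1` gives 11.4 ug/mL. Compound 2 has the lowest of these three numbers, but the other two lie within the scatter of it, so no real order among the three can be claimed.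

Compound 4 `CN(C(=O)NC(=O)c1cccc([N+](=O)[O-])c1)c1nc(C(F)(F)F)c(C(=O)N/N=C/c2ccccc2C(F)(F)F)s1` has not been measured. It differs from compound 2 in one place: 3-nitrophenyl in place of 2,6-dichlorophenyl on a carbonyl carbon. Among the compounds with values here, only one measured step touches this same spot, namely a 1.2-fold lower number from compound 1 to compound 2 (0.07 log units; within the scatter), and it stayed within the scatter. That is the whole of the evidence bearing on the change, and it gives no reason to expect a shift beyond the scatter in this assay in either direction. The expected outcome is therefore the step of a 1.1-fold higher number from compound 2 to compound 4 (0.03 log units; within the scatter). Compound 4 is estimated at 9.5 ug/mL, with a range from 5 ug/mL to 19 ug/mL.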

Compound 4, half-maximal inhibitory concentration: 4.8 ug/mL
The estimate for compound 4 lay 2.0-fold (0.30 log units) above the measured number; measured number below the stated range.
By their numbers in this assay, from the lowest: compounds 4, 2, 1 and 3 (each within the scatter of the next, the first and the last beyond it).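

In this assay this spot on a carbonyl carbon now shows its first step beyond the scatter: nitro in place of trifluoromethyl on an aromatic carbon gives a 2.2-fold lower number from compound 1 to compound 4 (0.34 log units; beyond the scatter) and so a single group on this ring can shift the number, if only modestly. The other change, 3-nitrophenyl in place of 2,6-dichlorophenyl, gives a 1.9-fold lower number from compound 2 to compound 4 (0.27 log units; within the scatter) and cannot be told apart from no change at all. Nothing measured here explains what sets nitro apart from trifluoromethyl.

Open, from the compounds shown here alone, is whether this shift is particular to nitro, or whether other groups on the ring would produce it too. An amine, a nitrile or a carboxylic acid in that place would help to settle this, and a single modest step cannot yet support a trend.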